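Amide-nitrogen substituent in the catechol diether amide series

The source may hold more compounds than are shown below. What is called first, only, known or untested is meant among the compounds shown, and "the series" means these compounds.

Compound 2 `COc1ccc(C(=O)Nc2ncccc2C)cc1OC1CCCC1` stands at the higher of the two numbers in an assay on isolated protein for inhibition of phosphodiesterase 4A (Sus scrofa); a lower number here means a stronger inhibitor, a higher number a weaker inhibitor: compound 2 gives 3100 nM, while compound 1 `COc1ccc(C(=O)Nc2c(F)cccc2F)cc1OC1CCCC1` gives 70 nM. Among the compounds with values here, the one step so far, a 44-fold higher number from compound 1 to compound 2 (1.65 log units; beyond the scatter), shows that the group on the amide-type nitrogen moves the number strongly. Compound 3 `COc1ccc(C(=O)NN2C(Cl)=NC=CC2Cl)cc1OC1CCCC1` carries a group of 8 heavy atoms (4 carbon, 2 nitrogen, 2 chlorine; one six-membered non-aromatic ring with 2 hetero atoms) in place of a group of 7 heavy atoms (6 carbon, 1 nitrogen; one six-membered aromatic ring with 1 hetero atom), on an amide-type nitrogen. Within the data shown here, no measured step covers a chlorinated non-aromatic ring here, so only the size of the change is a guide; in this assay compound 3 is expected at 3500 nM, within 700 nM to 17000 nM. The expected step is a 1.1-fold higher number from compound 2 to compound 3 (0.05 log units; within the scatter), not beyond the scatter.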

Compound 3, half-maximal inhibitory concentration: 400 nM
Compound 3: middle estimate off by 8.8-fold (0.94 log units), on the high side, outside the stated range (below it).
By their numbers in this assay, from the lowest: compound 1; then compound 3; then compound 2.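

The group on the amide-type nitrogen need not be aromatic: the chlorinated six-membered non-aromatic ring gives a 7.8-fold lower number from compound 2 to compound 3 (0.89 log units; beyond the scatter), so 3-methylpyridin-2-yl is not the better of these two groups. That ring still falls short of 2,6-difluorophenyl, with a 5.7-fold higher number from compound 1 to compound 3 (0.76 log units; beyond the scatter). No evidence is available that bears on either step.

Going by these compounds, whether the chlorine atoms or the non-aromatic ring carries the gain stays open, since the two change together here; an unsubstituted phenyl or a piperidin-1-yl group on this nitrogen would separate them.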